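Thiophene attachment point in a pyridine series: topoisomerase inhibition

This account rests on a few compounds, and the source may have more. Where it says the series, first, only, none or still open, it means among the compounds named here.

Measured so far in an assay on isolated protein for inhibition of DNA topoisomerase 1 (Homo sapiens), with a stated time of 30 min, tested at 100 uM; a higher number here means a stronger effect of the compound at the concentration tested, a lower number a weaker effect:

compound 1 `Oc1ccc(-c2cc(-c3ccc(Cl)cc3)nc(-c3cccs3)c2)cc1` — compound 1 gives 38.8%
compound 2 `Oc1ccc(-c2cc(-c3ccc(Cl)cc3)nc(-c3ccsc3)c2)cc1` — compound 2 gives 47.7%
compound 3 `Oc1cccc(-c2cc(-c3ccsc3)nc(-c3cccc(Cl)c3)c2)c1` — compound 3 gives 26.2%

Within the pair compound 2 and compound 1, the change is thiophen-2-yl in place of thiophen-3-yl on an aromatic carbon, and the step is a number 8.9 percentage points lower from compound 2 to compound 1 (within the scatter). The core of compound 3 differs from that of compound 2, but the difference between the two cores is not broken down here. Compound 3 has the lowest number of the three in this assay, beyond the scatter against both others.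

Compound 4 `Oc1cccc(-c2cc(-c3cccc(Cl)c3)nc(-c3cccs3)c2)c1` is not yet measured. It differs from compound 3 by thiophen-2-yl in place of thiophen-3-yl on an aromatic carbon. This is the same kind of change as that from compound 2 to compound 1, though not the same: around the place, compound 4 carries a 3-chlorophenyl group and a 3-hydroxyphenyl group where compound 1 carries a 4-chlorophenyl group and a 4-hydroxyphenyl group. Because the earlier step was a number 8.9 percentage points lower from compound 2 to compound 1 (within the scatter), a step of similar size is expected, a number 4.2 percentage points lower from compound 3 to compound 4 (within the scatter), small and within the scatter. Compound 4 is estimated at 22%, with a range from 8% to 36%.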

Compound 4, a percentage reported as inhibition, at one concentration (the size of the read-out at that concentration, not a potency): 7.6%
Estimate against measurement, compound 4: 14.4 percentage points above; measured number outside the range, below it.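

In this assay, thiophen-2-yl in place of thiophen-3-yl on the core of compound 3 gives a number 18.6 percentage points lower from compound 3 to compound 4 (beyond the scatter). Set beside the same change on the core of compound 2, the two steps cannot be told apart in size: the same change on two cores in this assay, a number 8.9 percentage points lower (within the scatter) from compound 2 to compound 1 and a number 18.6 percentage points lower (beyond the scatter) from compound 3 to compound 4, 9.7 percentage points apart, within the scatter of two such steps. This fits a change that carries across the two cores, which differ in having 3-chlorophenyl and 3-hydroxyphenyl groups or 4-chlorophenyl and 4-hydroxyphenyl groups, but two pairs, one with a step within the scatter, set neither a fixed size for the change nor a rule for any other core.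

Still open, from the compounds shown here alone, is whether the step holds when the hydroxyl of the hydroxyphenyl group gives way to an amine, or the chlorine to a carboxylic acid, and how a furan ring would compare with either thiophene. All the numbers are read-outs at a single concentration, so they show only a stronger or weaker effect at that concentration.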